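Swapping the aryl group on a fused-ring oxime series

The source may hold more compounds than are shown below. What is called first, only, known or untested is meant among the compounds shown, and "the series" means these compounds.

Of the compounds shown here, two have been measured in an assay on HepG2 cells for agonist activity at nuclear receptor subfamily 1 group I member 3 (Homo sapiens), read by a luciferase reporter, with a stated time of 23 h; a lower number here means that less compound is needed, a higher number that more compound is needed for the effect. Compound 1 `Clc1ccc(CO/N=C/c2c(-c3ccc4ccccc4c3)nc3occn23)c(Cl)c1` gives 1500 nM. Compound 2 `CC(C)c1ccc(-c2nc3sccn3c2/C=N/OCc2ccc(Cl)c(Cl)c2)cc1` gives 590 nM, the lower of the two numbers, and its gap to compound 1 is beyond the scatter of this assay. Among the compounds with values here, no pair of measured compounds differs in a single place, so no direct step can be read from the data.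

Compound 3 `Clc1cccc(-c2nc3sccn3c2/C=N/OCc2ccc(Cl)c(Cl)c2)c1` is the next compound to be tested. It differs from compound 2 in one place: 3-chlorophenyl in place of 4-isopropylphenyl on an aromatic carbon. Within the data shown here, nothing measured so far shows how this assay responds to this particular exchange, so the direction is uncertain; a small step, possibly within the scatter, is expected. Compound 3 is estimated to give 400 nM, within a range from 150 nM to 1500 nM, which would be a step of a 1.5-fold lower number from compound 2 to compound 3 (0.17 log units; within the scatter).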

Compound 3, half-maximal effective concentration: 1100 nM
Estimate against measurement, compound 3: 2.8-fold (0.44 log units) below; measured number inside the range.
By their numbers in this assay, from the lowest: compounds 2, 3 and 1 (each within the scatter of the next, the first and the last beyond it).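

Exchanging 4-isopropylphenyl for 3-chlorophenyl on this aromatic carbon, the first single-place change available in the series, gives a 1.9-fold higher number from compound 2 to compound 3 (0.27 log units; within the scatter) in this assay. At this position, then, two differently substituted phenyl rings cannot be told apart by this read-out, even though the group that enters is the smaller by heavy atoms and carries chlorine rather than a branched carbon chain. Nothing measured here offers an explanation for this result.

Going by these compounds, two phenyl groups say little about the full range this position accepts, so it remains open whether a carboxylic acid or an amine on the ring, or a longer alkyl chain, would stay within the scatter or move the number clearly. On these data alone, it is also open whether the same exchange would behave alike on the core of compound 1.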